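The compounds below may be only part of what the source reports. "The series", "measured", "known", "first", "only" and "open" are said of these compounds alone.

Compound 1, `Cc1cccc(-n2nncc2CN2C(=O)C3(C(C#N)=C(N)Oc4c3c3nc5ccccc5nc3c3ccccc43)c3ccccc32)c1`, is the starting point of this small series. In a functional assay on MCF7 cells (Homo sapiens) for antiproliferative activity, read by MTT assay, with a stated time of 48 h (on this read-out lower numbers stand for stronger inhibition and higher numbers for weaker inhibition), compound 1 gives no number but only a limit, > 50000 nM; this is the limit of > 50000 nM in this assay, at which 1 of the 3 values shown sits. Compound 2, `N#CC1=C(N)Oc2c(c3nc4ccccc4nc3c3ccccc23)C12C(=O)N(Cc1cnnn1-c1cccc(Cl)c1)c1ccccc12`, carries a chloro in place of the methyl on an aromatic carbon and gives 43600 nM in this assay. Compound 3, `N#CC1=C(N)Oc2c(c3nc4ccccc4nc3c3ccccc23)C12C(=O)N(Cc1cnnn1-c1ccc(Br)cc1)c1ccccc12`, carries 4-bromophenyl on an aromatic nitrogen and gives 36600 nM in this assay. The step of a 1.2-fold lower number from compound 2 to compound 3 (0.08 log units; within the scatter) is within the scatter, so compound 3 stands together with compound 2 rather than apart from it; the steps of an at least 1.1-fold lower number from compound 1 to compound 2 (0.05 log units; that floor lies within the scatter) and an at least 1.3-fold lower number from compound 1 to compound 3 (0.13 log units; that floor lies within the scatter) are only floors set by the limit of compound 1.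

Compound 4, `N#CC1=C(N)Oc2c(c3nc4ccccc4nc3c3ccccc23)C12C(=O)N(Cc1cnnn1-c1ccccc1Br)c1ccccc12`, differs from compound 3 by 2-bromophenyl in place of 4-bromophenyl on an aromatic nitrogen. Within the data shown here, none of the measured steps moves the bromine around the ring; the three steps seen so far, all within the scatter, show that swapping one aryl group for another leaves the number in the same weak region. The step of a 1.1-fold higher number from compound 3 to compound 4 (0.04 log units; within the scatter) is therefore expected to stay within the scatter. Compound 4 is estimated at 40000 nM in this assay, with a range from 15000 nM to 150000 nM.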

Compound 4, half-maximal inhibitory concentration: > 50000 nM
Compound 4 ended at the assay's limit; the forecaster's own chance of this, stated with the estimate: 35%; middle value at least 1.2-fold (0.09 log units) from the limit.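

Moving the bromine from 4-bromophenyl to 2-bromophenyl keeps the same atoms and changes only how they are joined, and in this assay this gives an at least 1.3-fold higher number from compound 3 to compound 4 (0.13 log units; that floor lies within the scatter), alongside an at least 1.1-fold higher number from compound 2 to compound 4 (0.05 log units; that floor lies within the scatter); neither floor shows a real loss of activity. Compound 4 gives > 50000 nM, which is a limit, and its step from compound 1 cannot be read. Even this shift of the bromine around the ring leaves the series in the same weak region, now with a second compound at the limit: the limit of > 50000 nM in this assay, at which 2 of the 4 values shown sit.

The compounds shown leave open whether any other group on this phenyl ring, such as a methoxy, an amine or a carboxylic acid in place of the bromine, would clearly lower the number. They also leave open how large the true gap between the two bromophenyl compounds is.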